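The source may report more compounds than this note shows. Statements on the series, on what has been measured and on what is new or still open speak of the compounds shown alone.

Measured compounds:
- Compound 1 `O=C(NCc1ccccc1)c1cc(Oc2ccc(/C=C/c3ccccn3)cc2)ccn1`: 18800 nM
- Compound 2 `CNC(=O)c1cc(Oc2ccc(/C=C/c3ccncc3)cc2)ccn1`: 13200 nM
- Compound 3 `O=C(Nc1ccccc1)c1cc(Oc2ccc(/C=C/c3ccncc3)cc2)ccn1`: 79700 nM

All three compounds were tested in a functional assay on A549 cells (Homo sapiens) for antiproliferative activity, read by CCK-8 assay, with a stated time of 48 h; on this read-out lower numbers stand for stronger inhibition and higher numbers for weaker inhibition. Among them compound 3 stands at the highest number, that is, it is the weakest of the three; its nearest neighbour is compound 1 at a lower number, and compound 2 lies lower still. All three share the same core, a pyridine amide carrying a diaryl ether and a stilbene-like arm ending in a pyridine, and they differ in the group on the amide nitrogen and in the placement of the pyridine nitrogen on that arm.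

The step under discussion leads from compound 3 to compound 4 `O=C(NCc1ccccc1)c1cc(Oc2ccc(/C=C/c3ccncc3)cc2)ccn1`, which has not yet been measured. The change is benzyl in place of phenyl on an amide-type nitrogen.

Within the data shown here, only one measured step touches this amide-type nitrogen: a 6.0-fold higher number from compound 2 to compound 3 (0.78 log units; beyond the scatter). Among the measured compounds shown here, no measured step covers the exchange of phenyl for benzyl directly. Compound 1, which also carries benzyl on the amide-type nitrogen but has its pyridine nitrogen placed differently, gives 18800 nM in this assay; compound 1 and compound 3 differ in two places, so their values can only be set side by side.

Taking these numbers together, the expectation is that compound 4 moves back toward compound 1 and compound 2, with a step of a 4.0-fold lower number from compound 3 to compound 4 (0.60 log units; beyond the scatter) toward a lower number. Compound 4 is therefore estimated at 20000 nM, within a range of 8000 nM to 50000 nM.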

Compound 4, half-maximal inhibitory concentration: 17000 nM
Compound 4: middle estimate off by 1.2-fold (0.07 log units), on the high side; low and high end bracket the measured number.
By their numbers in this assay, from the lowest: compounds 2, 4 and 1 (each within the scatter of the next); then compound 3.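

In this assay, benzyl in place of phenyl on the amide-type nitrogen gives a 4.7-fold lower number from compound 3 to compound 4 (0.67 log units; beyond the scatter), so a larger group on this nitrogen does not by itself bring the high number seen with compound 3. Methyl and benzyl cannot be told apart at this position, since a 1.3-fold higher number from compound 2 to compound 4 (0.11 log units; within the scatter) lies within the scatter, whereas phenyl stands apart from methyl with a 6.0-fold higher number from compound 2 to compound 3 (0.78 log units; beyond the scatter); among these three groups, only phenyl goes with a clear loss of activity. Among these compounds, the new compound also gives the first one-place comparison of the pyridine on the arm: pyridin-4-yl in place of pyridin-2-yl, with benzyl on the amide-type nitrogen, gives a 1.1-fold lower number from compound 1 to compound 4 (0.04 log units; within the scatter), which is within the scatter, so this exchange shows no measurable effect here.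

On these data alone, it remains open whether a longer chain such as phenylethyl on the amide-type nitrogen would stay at the level of benzyl, and whether pyridin-3-yl on the arm would match pyridin-2-yl and pyridin-4-yl. Nothing at hand explains why phenyl stands apart from benzyl and methyl at this nitrogen.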